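Fluoro for Hydrogen on the Benzylsulfanyl Arm of Compound 2

The source may hold more compounds than are shown below. What is called first, only, known or untested is meant among the compounds shown, and "the series" means these compounds.

Of the compounds shown here, two built on a shared core have been tested in a functional assay on the whole organism (artery, strain albino) with Rattus norvegicus as the target, with a stated time of 120 min, at a dose of 10 mg/kg by the oral route; on this read-out higher numbers stand for more inhibition at the one dose given (going by the name of the read-out) and lower numbers for less inhibition. Compound 1 `CC1=C(C(=O)Nc2ccc(F)cc2)C(c2ccc([N+](=O)[O-])cc2)N=C(SCc2ccc(F)cc2)N1` gives 17% in this assay. Compound 2 `CC1=C(C(=O)Nc2ccc(Br)cc2)C(c2ccc(Cl)cc2Cl)N=C(SCc2ccccc2)N1` gives 10.3% in this assay, the lowest of the two numbers, but the gap to compound 1 lies within the scatter, so the two read-outs show no difference that can be called real. The two structures differ in several places at once, so their pair says nothing about any single change.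

Compound 3 `CC1=C(C(=O)Nc2ccc(Br)cc2)C(c2ccc(Cl)cc2Cl)N=C(SCc2ccc(F)cc2)N1` is still to be measured. It differs from compound 2 in one place: fluoro in place of hydrogen on an aromatic carbon. Among the compounds with values here, no pair of measured compounds is separated by this change alone, so there is no measured step to lean on. Because compound 2 gives only 10.3%, and compound 1, which already carries the 4-fluorobenzyl group, also sits low, no shift beyond the scatter is expected in either direction. Compound 3 is estimated to give 12% in this assay, with a range from 0% to 28%, which means an expected step of a number 1.7 percentage points higher from compound 2 to compound 3 (within the scatter).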

Compound 3, a percentage reported as inhibition, in the whole organism at one dose (the size of the read-out at that dose, not a potency): 22.7%
For compound 3 the middle estimate is 10.7 percentage points below the measured one; the measured number falls inside the stated range.
By their numbers in this assay, from the lowest: compounds 2, 1 and 3 (each within the scatter of the next, the first and the last beyond it).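

In this assay, within the data shown here, the change from benzylsulfanyl to (4-fluorobenzyl)sulfanyl gives a number 12.4 percentage points higher from compound 2 to compound 3 (beyond the scatter) and is the first comparison that isolates a single place, which the earlier pair of compounds, differing in several places at once, could not do. It shows that this aromatic carbon, para to a large group on the benzyl ring, is not a silent position: one fluoro atom in place of hydrogen, with the rest of the molecule unchanged, moves the inhibition seen at the one oral dose by a modest amount beyond the scatter, although this rests on one pair and gives no measure of potency. Nothing measured here explains why the fluoro has this effect, and no property of either compound is on hand to account for it.

The compounds shown leave open whether a chloro, a methoxy or an amine on the same carbon would give a similar, larger or smaller step. They also leave open whether the fluoro would give the same step on a molecule that differs from compound 2 elsewhere, so the step cannot yet be carried over to the rest of the series.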